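The source may report more compounds than this note shows. Statements on the series, on what has been measured and on what is new or still open speak of the compounds shown alone.

Measured so far:
compound 1 `Cc1cc(=O)n(-c2cccc(F)c2)nc1C(=O)Nc1ccc(Oc2ncnc3[nH]ccc23)cc1` — in a functional assay on HepG2 cells (Homo sapiens) for cytotoxicity, read by MTT assay, with a stated time of 72 h (a lower number here means a stronger inhibitor, a higher number a weaker inhibitor), compound 1 gives 3180 nM
compound 2 `Cc1cc(=O)n(-c2ccc(F)cc2)nc1C(=O)Nc1ccc(Oc2ncnc3[nH]ccc23)c(F)c1` — in this assay compound 2 gives 12900 nM

Of these two numbers, compound 2 holds the higher one; compound 1 sits at a lower number, and the gap between them lies beyond the usual scatter. Compound 3 `Cc1cc(=O)n(-c2cccc(F)c2)nc1C(=O)Nc1ccc(Oc2ncnc3[nH]ccc23)c(F)c1` has not yet been measured. It differs from compound 2 by 3-fluorophenyl in place of 4-fluorophenyl on an aromatic nitrogen. Going by the values given here, no measured pair differs in this one place alone: compound 1 carries the 3-fluorophenyl but differs from compound 2 elsewhere as well, so its value cannot be read as the effect of this change by itself. The step from compound 2 to compound 3 in this assay is therefore expected to be modest, toward a lower number, and it may well fall within the scatter. The expected step is a 1.8-fold lower number from compound 2 to compound 3 (0.27 log units; within the scatter). Compound 3 is estimated to give 7000 nM, with a range from 2500 nM to 20000 nM.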

Compound 3, half-maximal inhibitory concentration: 23100 nM
Compound 3: middle estimate off by 3.3-fold (0.52 log units), on the low side; the measured number lies above the stated range.
By their numbers in this assay, from the lowest: compound 1; then compounds 2 and 3 (each within the scatter of the next).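

In this assay, 3-fluorophenyl in place of 4-fluorophenyl on the aromatic nitrogen gives a 1.8-fold higher number from compound 2 to compound 3 (0.25 log units; within the scatter) and so does not separate the two fluorophenyl groups at this position. Going by these compounds alone, the other single change, fluoro in place of hydrogen on an aromatic carbon, gives a 7.3-fold higher number from compound 1 to compound 3 (0.86 log units; beyond the scatter) and is the one step of the two that lies beyond the scatter. Nothing in the data given here accounts for either step.

Going by these compounds, it remains open whether the same fluoro on the aromatic carbon would give a step of similar size alongside the 4-fluorophenyl group. Also open, on these data alone, is how an unsubstituted phenyl, a chlorophenyl or a methoxyphenyl on the aromatic nitrogen would compare with the two fluorophenyl groups in this assay.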